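The source may hold more compounds than are shown below. What is called first, only, known or untested is meant among the compounds shown, and "the series" means these compounds.

Working notes on the series. All three measured compounds share one core and differ only in the group carried on an aromatic nitrogen. Compound 1 `Cc1ccc(-c2nn(-c3cccc(Cl)c3)cc2C(=O)Nc2ccc(C)c(S(=O)(=O)N3CCOCC3)c2)cc1` carries 3-chlorophenyl there, and in an assay on isolated protein for antagonist activity at Bile acid receptor (Homo sapiens), read by TR-FRET, with a stated time of 20 min, tested at 164 nM (on this read-out lower numbers stand for less inhibition and higher numbers for more inhibition at the one concentration tested (going by the name of the read-out)), compound 1 gives 99.3%. Compound 2 `Cc1ccc(-c2nn(-c3ccc(Cl)cc3Cl)cc2C(=O)Nc2ccc(C)c(S(=O)(=O)N3CCOCC3)c2)cc1` carries 2,4-dichlorophenyl; in this assay compound 2 gives 120%, the step being a number 20.7 percentage points higher from compound 1 to compound 2 (beyond the scatter). Compound 3 `Cc1ccc(-c2nn(Cc3ccc4ccccc4c3)cc2C(=O)Nc2ccc(C)c(S(=O)(=O)N3CCOCC3)c2)cc1` carries (naphthalen-2-yl)methyl; in this assay compound 3 gives 97.8%. Compound 3 sits at the low end of the three numbers: the step of a number 22.2 percentage points lower from compound 2 to compound 3 (beyond the scatter) lies beyond the scatter, whereas the step of a number 1.5 percentage points lower from compound 1 to compound 3 (within the scatter) does not, so compound 1 and compound 3 cannot be told apart on this read-out.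

Compound 4 `Cc1ccc(-c2nn(-c3ccccc3)cc2C(=O)Nc2ccc(C)c(S(=O)(=O)N3CCOCC3)c2)cc1` is not yet measured. It differs from compound 3 as follows: phenyl in place of (naphthalen-2-yl)methyl on an aromatic nitrogen. Phenyl is again an aryl group bound directly to the aromatic nitrogen, as in compound 1 and compound 2. Among the measured compounds shown here, the steps that bear on this change are a number 1.5 percentage points lower from compound 1 to compound 3 (within the scatter) and a number 22.2 percentage points lower from compound 2 to compound 3 (beyond the scatter); the only one beyond the scatter involved 2,4-dichlorophenyl, which compound 4 does not carry, and the closest analogy is compound 1 at 99.3%. For compound 4 in this assay no step beyond the scatter is therefore expected, a number 0.2 percentage points higher from compound 3 to compound 4 (within the scatter). Compound 4 is estimated at 98%, with a range from 85% to 112%.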

Compound 4, a percentage reported as inhibition, at one concentration (the size of the read-out at that concentration, not a potency): 100%
Estimate against measurement, compound 4: 2 percentage points below; measured number inside the range.
By their numbers in this assay, from the lowest: compounds 3, 1 and 4 (each within the scatter of the next); then compound 2.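

In this assay, bare phenyl on the aromatic nitrogen cannot be separated from either 3-chlorophenyl or (naphthalen-2-yl)methyl: the record shows a number 0.7 percentage points higher from compound 1 to compound 4 (within the scatter) for hydrogen in place of chloro and a number 2.2 percentage points higher from compound 3 to compound 4 (within the scatter) for the change from 11 heavy atoms to 6, with one six-membered aromatic ring left instead of 2. Neither the single chloro nor the larger group therefore registers on this read-out at the one concentration tested, while the 2,4-dichlorophenyl group stands apart from the unsubstituted phenyl, with a number 20 percentage points lower from compound 2 to compound 4 (beyond the scatter). Nothing available bears on why the 2,4-dichlorophenyl group alone stands apart.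

The four compounds do not settle whether the separation of the 2,4-dichlorophenyl group needs both chloro groups or one of them, which 2-chlorophenyl and 4-chlorophenyl groups on the same nitrogen would address. They also leave open how this position responds to groups of a different kind, such as a methyl group in place of the aryl group, or a phenyl ring carrying an amine or a carboxylic acid.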